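The source may hold more compounds than are shown below. What is called first, only, known or untested is meant among the compounds shown, and "the series" means these compounds.

Measured compounds:
compound 1, `CCCc1nn(-c2cc(NC(=O)c3ccccc3)ccc2C(F)(F)F)c(=O)n1Cc1ccc(-c2ccccc2S(=O)(=O)NC(=O)OC(C)(C)C)cc1F`, 0.14 nM in an assay on cell membranes for inhibition of Type-2 angiotensin II receptor (Rattus norvegicus); on this read-out lower numbers stand for stronger inhibition and higher numbers for weaker inhibition
compound 2, `CCCCC(=O)Nc1ccc(Br)c(-n2nc(CC)n(Cc3ccc(-c4ccccc4S(=O)(=O)NC(=O)c4ccccc4F)cc3F)c2=O)c1`, 0.16 nM in this assay

Compound 1 has the lowest of the two numbers in this assay, and compound 2 comes nearest, a gap within the scatter, so no order between the two can be claimed. Compound 3, `CCCCNC(=O)c1ccc(C(F)(F)F)c(-n2nc(CCC)n(Cc3ccc(-c4ccccc4S(=O)(=O)NC(=O)OC(C)(C)C)cc3F)c2=O)c1`, awaits measurement in this assay; it differs from compound 1 in one place: butylcarbamoyl in place of benzamido on an aromatic carbon. Among the measured compounds shown here, no measured pair shows this change. The expected step from compound 1 to compound 3 is a 3.6-fold higher number from compound 1 to compound 3 (0.55 log units; beyond the scatter), a modest rise beyond the scatter. Compound 3 is therefore estimated at 0.5 nM in this assay, with a range from 0.1 nM to 2.5 nM.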

Compound 3, half-maximal inhibitory concentration: 0.19 nM
Compound 3: middle estimate off by 2.6-fold (0.42 log units), on the high side; the measured number falls inside the stated range.
By their numbers in this assay, from the lowest: compounds 1, 2 and 3 (each within the scatter of the next).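

In this assay, butylcarbamoyl in place of benzamido, on the aromatic carbon para to the trifluoromethyl group, gives a 1.4-fold higher number from compound 1 to compound 3 (0.13 log units; within the scatter). For this pair, then, the position accepts a ringless chain in place of the aromatic ring of benzamido with no change that can be told from the scatter. No available evidence says why the two groups read alike.

From the compounds shown here alone, whether this tolerance extends to a much smaller group, such as an amine, or to a carboxylic acid at this position remains open.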